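The source may report more compounds than this note shows. Statements on the series, on what has been measured and on what is new or still open speak of the compounds shown alone.

Of the compounds shown here, three built on one shared core have been measured in a functional assay on CCRF-CEM cells (Homo sapiens) for inhibition; on this read-out higher numbers stand for weaker inhibition and lower numbers for stronger inhibition. There, compound 1 `Cn1cc(C#N)c2ccc(Nc3ncc(-c4ccccc4CN)o3)cc21` gives 1100 nM, compound 2 `Cn1cc(C#N)c2ccc(Nc3ncc(-c4cccc(CNC(=O)c5ccccc5)c4)o3)cc21` gives 5300 nM, and compound 3 `Cn1cc(C#N)c2ccc(Nc3ncc(-c4cccc(CNC(=O)c5ccc6ccccc6c5)c4)o3)cc21` gives 4400 nM. Compound 3 therefore sits level with compound 2 within the scatter, while the number for compound 1 is lower by more than the scatter, which means stronger inhibition.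

The next compound, compound 4 `Cn1cc(C#N)c2ccc(Nc3ncc(-c4cccc(CNC(=O)c5cccc6ccccc56)c4)o3)cc21`, has the same atoms as compound 3 joined differently, with naphthalen-1-yl in place of naphthalen-2-yl on a carbonyl carbon.

Going by the values given here, only one measured step bears on this change, the swap of phenyl for naphthalen-2-yl on that same carbonyl carbon, which gave a 1.2-fold lower number from compound 2 to compound 3 (0.08 log units; within the scatter). Among the compounds with values here, that step lies within the scatter, so the numbers so far show little response to the group at this place. Within the data shown here, it is a single step, however, and no measured pair compares the two naphthalene attachments directly, so the expectation has to stay wide.

No step beyond the scatter is expected in this assay, in either direction, and the estimated change is a 1.0-fold higher number from compound 3 to compound 4 (0.01 log units; within the scatter). For compound 4 the estimated value is 4500 nM, with an expected range from 2000 nM to 10000 nM.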

Compound 4, half-maximal inhibitory concentration: 2500 nM
The estimate for compound 4 lay 1.8-fold (0.26 log units) above the measured number, within the range that was stated.
By their numbers in this assay, from the lowest: compound 1; then compounds 4, 3 and 2 (each within the scatter of the next, the first and the last beyond it).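

Swapping naphthalen-2-yl for naphthalen-1-yl on the carbonyl carbon gives a 1.8-fold lower number from compound 3 to compound 4 (0.25 log units; within the scatter) in this assay, so the first direct comparison of the two naphthalene attachments finds no difference that can be told apart from ordinary repeat-to-repeat variation. Set against the phenyl group, however, naphthalen-1-yl gives a 2.1-fold lower number from compound 2 to compound 4 (0.33 log units; beyond the scatter), a modest step, but the first at this place to pass beyond the scatter, whereas the step from phenyl to naphthalen-2-yl did not, so the group on this carbonyl carbon has some measurable bearing on the read-out. Nothing available explains why this step clears the scatter, and the small size of the step gives it little weight on its own.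

Every group shown on this carbonyl carbon is an aromatic ring system of carbon only, so the response to a pyridine ring, a carboxylic acid, an amine or a short alkyl chain at this place remains unknown. Compound 1 also differs from the amides in more than one place, which leaves open which of those differences accounts for its separate standing in this assay.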